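The source may report more compounds than this note shows. Statements on the series, on what has been measured and on what is new or still open speak of the compounds shown alone.

Going by the values given here, compound 1 `COc1ccc(-c2cn3ccnc3c(-c3ccc4ncn(C5CCCCC5)c4c3)n2)cc1` gives 1.41 in a physicochemical assay for lipophilicity, using the shake flask method, in phosphate buffer, measured as octanol-water partition, with a stated time of 85 min, at pH 7.4 (on this read-out lower numbers stand for lower lipophilicity and higher numbers for higher lipophilicity), the lowest of the two numbers measured so far. Compound 2 `Clc1ccc(-c2cn3ccnc3c(-c3ccc4ncn(C5CCCCC5)c4c3)n2)cc1` gives 1.51 in this assay. Among the compounds with values here, the only measured step, a number 0.10 log units higher from compound 1 to compound 2 (within the scatter), is the one that bears on the change at hand. Compound 3 `Brc1ccc(-c2cn3ccnc3c(-c3ccc4ncn(C5CCCCC5)c4c3)n2)cc1` differs from compound 1 by bromo in place of methoxy on an aromatic carbon. Since chloro in place of methoxy moved the number only within the scatter, a similarly small rise is expected here, estimated as a number 0.24 log units higher from compound 1 to compound 3 (within the scatter). Compound 3 is therefore estimated at 1.65 in this assay, with a range from 1.35 to 1.95.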

Compound 3, partition coefficient: 1.73
Compound 3: the middle estimate sits 0.08 log units below what was measured, within the range that was stated.
By their numbers in this assay, from the lowest: compounds 1, 2 and 3 (each within the scatter of the next, the first and the last beyond it).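

Going by these compounds alone, on the aromatic carbon para to a large group, bromo in place of methoxy makes the first step here that passes the scatter in this assay (a number 0.32 log units higher from compound 1 to compound 3 (beyond the scatter)). Bromo in place of chloro stays inside it (a number 0.22 log units higher from compound 2 to compound 3 (within the scatter)), so these two groups cannot be told apart on this read-out, while only bromo stands clear of methoxy. Nothing available explains this difference. The compounds shown leave open how an amine or a carboxylic acid at this position would read. They also leave open whether the same change would hold with another group in place of the cyclohexyl ring.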